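Methoxy to hydroxy on the 4-methoxyphenyl group

The source may report more compounds than this note shows. Statements on the series, on what has been measured and on what is new or still open speak of the compounds shown alone.

In a functional assay on MDA-MB-231 cells (Homo sapiens) for inhibition, read by MTT assay, with a stated time of 48 h (on this read-out higher numbers stand for weaker inhibition and lower numbers for stronger inhibition), compound 1 (`COc1ccc(-c2cc(-c3cc(OC)c(OC)c(OC)c3)nc(-c3ccccc3)n2)c(OC)c1`) gives 1440 nM and compound 2 (`COc1ccc(-c2cc(-c3cc(OC)c(OC)c(OC)c3)nc(-c3ccccc3)n2)cc1`) gives 3390 nM, the higher of the two numbers. Compound 3 (`COc1cc(-c2cc(-c3ccc(O)cc3)nc(-c3ccccc3)n2)cc(OC)c1OC`) carries hydrogen in place of methyl on an oxygen on an aromatic ring, turning 4-methoxyphenyl to 4-hydroxyphenyl: hydrogen in place of methyl on an oxygen on an aromatic ring. For the measured compounds named here, one measured step bears on this, the modest 2.4-fold higher number from compound 1 to compound 2 (0.37 log units; beyond the scatter), which removes a whole methoxy elsewhere and so guides only loosely. No shift beyond the scatter is expected in this assay, and the estimated step is a 1.1-fold lower number from compound 2 to compound 3 (0.05 log units; within the scatter). Compound 3 is expected at 3000 nM, within an estimated range of 1200 nM to 8000 nM.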

Compound 3, half-maximal inhibitory concentration: 1600 nM
Estimate against measurement, compound 3: 1.9-fold (0.27 log units) above; the measured number falls inside the stated range.
By their numbers in this assay, from the lowest: compounds 1 and 3 (each within the scatter of the next); then compound 2.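

In this assay, hydrogen in place of methyl on an oxygen on an aromatic ring gives a 2.1-fold lower number from compound 2 to compound 3 (0.33 log units; beyond the scatter) and so shows that this position responds to a change at the oxygen, not only to removal of a whole methoxy. The swap of 2,4-dimethoxyphenyl for 4-hydroxyphenyl gives a 1.1-fold higher number from compound 1 to compound 3 (0.05 log units; within the scatter) and so leaves the two groups within the scatter. Nothing available explains either step.

From the compounds shown here alone, whether an amine or a carboxylic acid in place of the hydroxy would hold this number remains open. So does whether a longer alkoxy chain on that oxygen would return the number toward that of compound 2.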